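From fluoro to chloro on an aromatic carbon

A few compounds are considered here, and "the series" means these few. Any claim that something is new, unique, unknown or untested is made for them only; others in the source may bear on it.

Compound 1 `Nc1ccccc1NC(=O)c1ccc(CNC(=O)c2n[nH]cc2NC(=O)c2ccccc2Cl)cc1`: 10500 nM
Compound 2 `O=C(NO)c1ccc(CNC(=O)c2n[nH]cc2NC(=O)c2ccccc2F)cc1`: 6610 nM

Both numbers come from a functional assay on HeLa cells (Homo sapiens) for inhibition, read by CCK-8 assay, with a stated time of 72 h; on this read-out higher numbers stand for weaker inhibition and lower numbers for stronger inhibition. Compound 2 at 6610 nM lies within the usual scatter of compound 1, so on these numbers neither compound stands apart from the other.

Compound 3 `O=C(NO)c1ccc(CNC(=O)c2n[nH]cc2NC(=O)c2ccccc2Cl)cc1` has not yet been measured. It differs from compound 2 in one place: chloro in place of fluoro on an aromatic carbon. This is chloro in place of fluoro on an aromatic carbon, ortho to a large group. Among the compounds with values here, no pair of measured compounds shows this swap on its own, so the data offer no direct guide to its effect. The best starting point is compound 2 at 6610 nM, and no shift beyond the scatter is expected in this assay. The expected result is a 1.1-fold lower number from compound 2 to compound 3 (0.04 log units; within the scatter) as the estimated step. Compound 3 is estimated at 6000 nM in a expected range of 2500 nM to 14000 nM for now.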

Compound 3, half-maximal inhibitory concentration: 16200 nM
Estimate against measurement, compound 3: 2.7-fold (0.43 log units) below; the measured number lies above the stated range.
By their numbers in this assay, from the lowest: compounds 2, 1 and 3 (each within the scatter of the next, the first and the last beyond it).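

In this assay, chloro in place of fluoro on an aromatic carbon, ortho to a large group, gives a 2.5-fold higher number from compound 2 to compound 3 (0.39 log units; beyond the scatter) and so moves the read-out toward weaker inhibition. This shows that the read-out is sensitive to which of these two halogens sits at this position, even though the swap changes only a single heavy atom. At the other end of the molecule, with chloro held constant, hydroxy in place of 2-aminophenyl on an amide-type nitrogen gives a 1.5-fold higher number from compound 1 to compound 3 (0.19 log units; within the scatter) and does not separate the two compounds.

On these data alone, with only fluoro and chloro to compare, the effect of bromo, methyl, methoxy or plain hydrogen at this position remains open. Nothing in the available data explains the step from fluoro to chloro.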